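The source may hold more compounds than are shown below. What is called first, only, known or untested is meant among the compounds shown, and "the series" means these compounds.

Measured so far in an ADME assay on L02 cells (Homo sapiens) for cytotoxicity, read by MTT assay, with a stated time of 24 h; a higher number here means that more compound is tolerated, a lower number that less compound is tolerated:
- compound 1, `O=c1[nH]cc(S(=O)(=O)Nc2ccccc2-c2cn(-c3ccccc3Cl)nn2)c(=O)[nH]1`: 22800 nM
- compound 2, `O=c1[nH]cc(S(=O)(=O)Nc2ccccc2-c2cn(-c3cccc(Cl)c3)nn2)c(=O)[nH]1`: > 100000 nM
- compound 3, `O=c1[nH]cc(S(=O)(=O)Nc2cccc(-c3cn(-c4ccccc4Cl)nn3)c2)c(=O)[nH]1`: 11500 nM

The reading for compound 2 in this assay is a limit, not a number. Compound 2 differs from compound 1 by 3-chlorophenyl in place of 2-chlorophenyl on an aromatic nitrogen. This change gives an at least 4.3-fold higher number from compound 1 to compound 2 (0.64 log units; beyond the scatter); the step is open at its upper end because of the limit of > 100000 nM in this assay, at which 1 of the 3 values shown sits.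

Compound 3 has a different core from compound 1; the difference between the two cores is not broken down here. In this assay compound 3 gives 11500 nM, and compound 1 sits within the usual scatter of it, so no order between the two is claimed.

Compound 4, `O=c1[nH]cc(S(=O)(=O)Nc2cccc(-c3cn(-c4cccc(Cl)c4)nn3)c2)c(=O)[nH]1`, has not yet been measured in this assay. It differs from compound 3 by 3-chlorophenyl in place of 2-chlorophenyl on an aromatic nitrogen. The place of the change is the same, word for word, as in the move from compound 1 to compound 2, so this is the same change made on the core of compound 3.

Among the compounds with values here, the one measured instance of this change, an at least 4.3-fold higher number from compound 1 to compound 2 (0.64 log units; beyond the scatter), is the only basis for expectation. From compound 3 to compound 4 a step of a 4.3-fold higher number from compound 3 to compound 4 (0.64 log units; beyond the scatter) is expected in this assay. Compound 4 is estimated at 50000 nM, between 18000 nM and 150000 nM, with a real chance that this assay again reports only a limit.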

Compound 4, half-maximal cytotoxic concentration: 8330 nM
Compound 4: the middle estimate sits 6.0-fold (0.78 log units) above what was measured; the whole stated range lies above it.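

In this assay, 3-chlorophenyl in place of 2-chlorophenyl on the aromatic nitrogen gives a 1.4-fold lower number from compound 3 to compound 4 (0.14 log units; within the scatter), so the clear rise seen on the core of compound 1 does not carry over to the core of compound 3: the same change on two cores in this assay, an at least 4.3-fold higher number (0.64 log units; beyond the scatter) from compound 1 to compound 2 and a 1.4-fold lower number (0.14 log units; within the scatter) from compound 3 to compound 4, at least 6.0-fold (0.78 log units) apart, beyond the scatter of two such steps

The step on the core of compound 1 rests on a limit rather than a number, so its full size is unknown and it stays open at its upper end: the limit of > 100000 nM in this assay, at which 1 of the 4 values shown sits.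

Within the data shown here, the two pairs show that, in this series, the outcome of this change depends on the core it is made on, so a step measured on one core is a poor guide to the step on another; they do not show why the cores differ, and with only two pairs no rule follows for any further core.

On these data alone, it remains open whether a methoxy group or a carboxylic acid in place of the chlorine on the phenyl ring would follow the behaviour seen on the core of compound 1 or that seen on the core of compound 3. Also open, as far as these compounds go, is whether a phenyl ring without any chlorine would separate the two cores in the same way.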